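The compounds below may be only part of what the source reports. "The series", "measured", "known", "first", "only" and "open" are said of these compounds alone.

Compound 1 `FC(F)(F)Oc1ccc(-c2nc3cnc(Nc4ccccn4)cc3[nH]2)cc1` gives 62% 
Compound 2 `COc1ccnc(Nc2cc3[nH]c(-c4cccc(C(F)(F)F)c4)nc3cn2)c1` gives 62% 

In an ADME assay on microsomes from liver (Mus musculus) for metabolic stability, read by LC-MS, with a stated time of 30 min, tested at 0.1 uM (a lower number here means that less of the compound is left, a higher number that more of the compound is left), compound 2 reads 62% and so stands level with compound 1 at 62% within the usual scatter. Compound 3 `FC(F)(F)c1cccc(-c2nc3cnc(Nc4cnccn4)cc3[nH]2)c1` carries pyrazin-2-yl in place of 4-methoxypyridin-2-yl on a nitrogen on an aromatic ring and has not yet been measured. Going by the values given here, no measured pair isolates this swap. Among the compounds with values here, the only guides are compound 1 at 62% and compound 2 at 62% as two close readings. The estimated shift a number 2 percentage points higher from compound 2 to compound 3 (within the scatter) is small, with no change beyond the scatter expected. Compound 3 is expected at 64% with a likely range of 45% to 82% in this measurement.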

Compound 3, percent of the compound remaining: 7%
Compound 3: the middle estimate sits 57 percentage points above what was measured, and the stated range ends above it.
By their numbers in this assay, from the lowest: compound 3; then compounds 1 and 2 (each within the scatter of the next).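

In this assay, putting pyrazin-2-yl in place of 4-methoxypyridin-2-yl on a nitrogen on an aromatic ring gives a number 55 percentage points lower from compound 2 to compound 3 (beyond the scatter) with the rest of the molecule unchanged. This is the first single change shown at this position, and it shows that the ring on this nitrogen can strongly alter how much compound is left. Nothing measured here explains the drop.

The compounds shown leave open whether the loss of the methoxy group or the second ring nitrogen matters more, as this swap changes both at once. Also open, on these data alone, is how a pyrimidin-2-yl or 4-aminopyridin-2-yl group would read on this nitrogen.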